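Swapping the Aromatic Ring on a Shared Core

A few compounds are considered here, and "the series" means these few. Any claim that something is new, unique, unknown or untested is made for them only; others in the source may bear on it.

Compound 1 `CC1=CC[C@H](C(C)(C)NC(=S)N/N=C/c2ccccc2O)CC1`: 4600 nM
Compound 2 `CC1=CC[C@H](C(C)(C)NC(=S)N/N=C/c2ccccc2[N+](=O)[O-])CC1`: 68500 nM

In a functional assay on 786-0 cells (Homo sapiens) for inhibition, read by sulforhodamine B assay, with a stated time of 48 h (on this read-out lower numbers stand for stronger inhibition of growth and higher numbers for weaker inhibition of growth), compound 1 gives 4600 nM, the lowest of the two numbers measured. Compound 2 `CC1=CC[C@H](C(C)(C)NC(=S)N/N=C/c2ccccc2[N+](=O)[O-])CC1` differs from it only by a nitro in place of hydroxy on an aromatic carbon, and the step of a 15-fold higher number from compound 1 to compound 2 (1.17 log units; beyond the scatter) shows how much that one ring substituent matters. Compound 3 `CC1=CC[C@H](C(C)(C)NC(=S)N/N=C/c2ccc[nH]2)CC1` has not yet been measured. It differs from compound 1 in that (1H-pyrrol-2-yl in place of 2-hydroxyphenyl on a carbon with a double bond to nitrogen). Among the compounds with values here, no measured step covers this exchange of the whole ring; the only step available, a 15-fold higher number from compound 1 to compound 2 (1.17 log units; beyond the scatter), concerns a substituent on the ring that is now removed, so it offers a warning rather than a guide. With the ring that carries the strongest number replaced, compound 3 is expected to show a moderately higher number in this assay, with a 2.0-fold higher number from compound 1 to compound 3 (0.29 log units; within the scatter) as the estimated step. For compound 3 the estimate is therefore 9000 nM, with a range from 2500 nM to 35000 nM.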

Compound 3, concentration for 50% growth inhibition: 20800 nM
Compound 3: middle estimate off by 2.3-fold (0.36 log units), on the low side; low and high end bracket the measured number.
By their numbers in this assay, from the lowest: compound 1; then compound 3; then compound 2.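

In this assay, putting 1H-pyrrol-2-yl in place of 2-hydroxyphenyl gives a 4.5-fold higher number from compound 1 to compound 3 (0.66 log units; beyond the scatter), so the position tolerates a whole new ring, a five-membered one, with growth inhibition still measurable, though compound 1 stays ahead. Compound 3 falls between compound 1 and compound 2, so exchanging the entire ring raises the number less than the nitro on the phenyl ring does. No measurement at hand explains why the ring exchange has this effect.

Going by these compounds, it remains open how a plain phenyl ring with no substituent, or a pyridine ring, would compare at this position. Also unsettled is whether a methoxy group in place of the hydroxy, or a methyl group on the pyrrole ring, would bring the number closer to that of compound 1.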